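The source may hold more compounds than are shown below. What is called first, only, known or untested is meant among the compounds shown, and "the series" means these compounds.

The shared core of compound 1 `Cc1ccc2nc(C(=O)Nc3c(F)cc(-c4cccc(F)c4)cc3F)c(C)c(O)c2c1` carries a methyl group on its aromatic six-membered ring, and in a functional assay on Hep 3B2 cells (Homo sapiens) for antiproliferative activity, read by MTT assay, with a stated time of 24 h, tested at 1.23 ug/mL (on this read-out higher numbers stand for a stronger effect at the one concentration tested and lower numbers for a weaker effect), compound 1 gives 11.2%. Among the three measured compounds this places compound 1 second highest. Compound 2 `Cc1c(C(=O)Nc2c(F)cc(-c3cccc(F)c3)cc2F)nc2ccc(F)cc2c1O` carries a fluoro group at that position, and in this assay compound 2 gives 15.3%; the step of a number 4.1 percentage points higher from compound 1 to compound 2 (within the scatter) stays within the scatter. Compound 3 `CCOc1ccc2nc(C(=O)Nc3c(F)cc(-c4cccc(F)c4)cc3F)c(C)c(O)c2c1` carries an ethoxy group there, and in this assay compound 3 gives 1.03%; the step of a number 10.2 percentage points lower from compound 1 to compound 3 (beyond the scatter) lies beyond the scatter, as does the step of a number 14.3 percentage points lower from compound 2 to compound 3 (beyond the scatter).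

Compound 4 `Cc1c(C(=O)Nc2c(F)cc(-c3cccc(F)c3)cc2F)nc2ccc(C(F)(F)F)cc2c1O` arises from compound 1 through the change (trifluoromethyl in place of methyl on an aromatic carbon). The two steps that bear on it, fluoro for methyl and ethoxy for methyl at the same carbon, show that a small group in place of methyl left the number within the scatter, while the larger ethoxy group brought a modest drop. Trifluoromethyl is larger than fluoro but smaller than ethoxy, so a step at most near the edge of the scatter is expected in this assay, with a downward lean. The expected number for compound 4 is 9.5%, between 2% and 20%, and the expected step is a number 1.7 percentage points lower from compound 1 to compound 4 (within the scatter).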

Compound 4, a percentage reported as inhibition, at one concentration (the size of the read-out at that concentration, not a potency): 15.3%
The estimate for compound 4 lay 5.8 percentage points below the measured number; the measured number falls inside the stated range.
By their numbers in this assay, from the lowest: compound 3; then compounds 1, 2 and 4 (each within the scatter of the next).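

In this assay, trifluoromethyl, with 4 heavy atoms where methyl has 1, leaves the number at this aromatic carbon within the scatter (a number 4.1 percentage points higher from compound 1 to compound 4 (within the scatter)), so the modest drop seen with ethoxy does not follow from every replacement of methyl by a group with more heavy atoms. Among the four groups now compared at this carbon, ethoxy alone stands apart from the others, as the step to trifluoromethyl shows (a number 14.3 percentage points higher from compound 3 to compound 4 (beyond the scatter)), whereas trifluoromethyl and fluoro cannot be told apart on this read-out (no change at the digits printed from compound 2 to compound 4 (within the scatter)). Nothing in the available data explains why ethoxy differs from the other groups at this position.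

The compounds shown leave open whether the lower number belongs to ethoxy specifically or would also appear with methoxy, a longer alkoxy chain, a hydroxyl group, an amine or a carboxylic acid at this carbon. Since each compound is described by its inhibition at a single concentration, they also leave open whether methyl, fluoro and trifluoromethyl would remain indistinguishable across a range of concentrations.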